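The compounds below may be only part of what the source reports. "The series", "measured", "known", "first", "only" and "open" are said of these compounds alone.

Values in an ADME assay on KB cells (Homo sapiens) for cytotoxicity, read by MTT assay, with a stated time of 72 h; on this read-out lower numbers stand for stronger inhibition and higher numbers for weaker inhibition:
Compound 1 `COC(=O)c1cc(C2=C(c3cc(OC)c(OC)c(OC)c3)C(=O)CC2O[SiH2]C(C)(C)C)ccc1OC`: > 100 ug/mL (a limit)
Compound 2 `COc1ccc(C2=C(c3cc(OC)c(OC)c(OC)c3)C(=O)CC2O[SiH2]C(C)(C)C)cc1OC`: > 100 ug/mL (a limit)
Compound 3 `COc1ccc(C2=C(c3cc(OC)c(OC)c(OC)c3)C(=O)CC2O)cc1`: "not determined" (no result reported)

Compound 2 has no numerical value in this assay. Compound 2 gives > 100 ug/mL, which is a limit and not a number. It therefore stands at the limit of > 100 ug/mL in this assay, at which 2 of the 3 values shown sit. Compound 1 is the other compound at this limit, and compound 3 offers no result to compare.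

The next compound is compound 4 `COCOc1cc(C2=C(c3cc(OC)c(OC)c(OC)c3)C(=O)CC2O[SiH2]C(C)(C)C)ccc1OC`, which differs from compound 2 by methoxy in place of hydrogen on a saturated chain carbon bound to an oxygen on an aromatic ring. Cut one bond further out, this is methoxy to methoxymethoxy, turning 3,4-dimethoxyphenyl into 4-methoxy-3-(methoxymethoxy)phenyl.

Among the compounds with values here, only one measured step bears on this change, and it concerns a different group: a step that the two limits leave unreadable from compound 1 to compound 2. That step, methoxy in place of methoxycarbonyl, gives no size to carry over. Neither its direction nor its magnitude can be read from the two limits. What remains is that both measured compounds sit at the same limit, so no clear gain in inhibition is expected, and a further limit is the likeliest report. The expected change is a number no higher from compound 2 to compound 4 (the limit leaves the size open), with no step beyond the scatter anticipated. For compound 4 the estimated value is 100 ug/mL, with an expected range from 25 ug/mL to 200 ug/mL.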

Compound 4, half-maximal inhibitory concentration: 33 ug/mL
Beside the measured number, compound 4's estimate is 3.0-fold (0.48 log units) above it, and the stated range covers the measured number.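

In this assay compound 4 is the only compound shown that carries a number, 33 ug/mL. The other two measured compounds give no number at all, only a limit: the limit of > 100 ug/mL in this assay, at which 2 of the 4 values shown sit. Extending methoxy to methoxymethoxy at this place on the ring, with the rest of the structure unchanged, gives an at least 3.0-fold lower number from compound 2 to compound 4 (0.48 log units; beyond the scatter), and methoxymethoxy in place of methoxycarbonyl gives an at least 3.0-fold lower number from compound 1 to compound 4 (0.48 log units; beyond the scatter), so the read-out does respond to the group carried here, and both steps lie beyond the usual scatter.

On these data alone, the full size of both steps stays open, as each starts from a limit, and a single compound cannot tell whether the added methoxy or the longer chain as a whole accounts for the change. As far as these compounds go, whether a free hydroxy, an ethoxy or a longer ether chain such as methoxyethoxy at this place would give a lower number still, or lose the effect, also remains open.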